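A few compounds are considered here, and "the series" means these few. Any claim that something is new, unique, unknown or untested is made for them only; others in the source may bear on it.

Measured so far:
compound 1, `CCSc1nc(N)c2nc(O)n(Cc3ccccc3)c2n1`: 0.1 uM
compound 2, `NNc1nc2c(N)ncnc2n1Cc1ccccc1`: > 10 uM

Among the measured compounds shown here, compound 1 is the only compound of the pair with a definite number in a functional assay (spleen, spleen) for activation, with Mus musculus as the target; a lower number here means that less compound is needed, a higher number that more compound is needed for the effect; in this assay compound 1 gives 0.1 uM. Compound 2 returns only a limit of the assay in this assay, > 10 uM, as recorded in the limit of > 10 uM in this assay, at which 1 of the 2 values shown sits. For the measured compounds named here, no step between two measured compounds is available, so the move to compound 3 rests on compound 1 alone. Compound 3, `CSc1nc(N)c2nc(O)n(Cc3ccccc3)c2n1`, differs from compound 1 by hydrogen in place of methyl on a saturated chain carbon bound to a sulfur. Going by the values given here, with no measured step to draw on, the step of a 2.0-fold higher number from compound 1 to compound 3 (0.30 log units; within the scatter) is expected to be small, toward a somewhat higher minimum effective concentration, and not clearly beyond the usual scatter. Compound 3 is therefore estimated at 0.2 uM, with a range from 0.07 uM to 0.6 uM.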

Compound 3, minimum effective concentration: 0.1 uM
For compound 3 the middle estimate is 2.0-fold (0.30 log units) above the measured one; the range from low to high includes it.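

In this assay, the change from ethylsulfanyl to methylsulfanyl gives no change at the digits printed from compound 1 to compound 3 (within the scatter), and this is the only step shown at this place. On a saturated chain carbon bound to a sulfur, hydrogen in place of methyl therefore leaves the minimum effective concentration within the scatter, so this pair does not separate the ethyl and methyl ends of the chain. Nothing on record bears on why this step is flat.

Still open, on these data alone, is whether a longer chain such as butyl, a branched chain such as isopropyl, or an amine in place of the ethylsulfanyl group would keep the minimum effective concentration of compound 1. Also open, as far as these compounds go, is how a free thiol, with hydrogen directly on the sulfur, would read in this assay on the same core.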